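From 2,5-Difluorobenzyl to Methyl on the Shared Core

The source may hold more compounds than are shown below. What is called first, only, known or untested is meant among the compounds shown, and "the series" means these compounds.

In a functional assay on Bel7402/5-FU cells (Homo sapiens) for antiproliferative activity, read by MTT assay, with a stated time of 72 h (a lower number here means a stronger inhibitor, a higher number a weaker inhibitor), compound 1 `C=C1C(=O)O[C@H]2[C@H]1CC/C(COC(=O)Cn1cc(F)c(=O)n(Cc3ccccc3)c1=O)=C\CC[C@@]1(C)O[C@@H]21` gives 4270 nM, compound 2 `C=C1C(=O)O[C@H]2[C@H]1CC/C(COC(=O)Cn1cc(F)c(=O)n(Cc3ccc(F)cc3)c1=O)=C\CC[C@@]1(C)O[C@@H]21` gives 1140 nM and compound 3 `C=C1C(=O)O[C@H]2[C@H]1CC/C(COC(=O)Cn1cc(F)c(=O)n(Cc3cc(F)ccc3F)c1=O)=C\CC[C@@]1(C)O[C@@H]21` gives 4610 nM. Compound 3 thus stands with compound 1, since a 1.1-fold higher number from compound 1 to compound 3 (0.03 log units; within the scatter) lies within the scatter, whereas a 4.0-fold higher number from compound 2 to compound 3 (0.61 log units; beyond the scatter) lies beyond it. Compound 4 `C=C1C(=O)O[C@H]2[C@H]1CC/C(COC(=O)Cn1cc(F)c(=O)n(C)c1=O)=C\CC[C@@]1(C)O[C@@H]21` brings (hydrogen in place of 2,5-difluorophenyl on a saturated chain carbon bound to an aromatic nitrogen), hydrogen in place of 2,5-difluorophenyl on a saturated chain carbon bound to an aromatic nitrogen. The nearest guides are those two steps and a 3.7-fold lower number from compound 1 to compound 2 (0.57 log units; beyond the scatter), all modest or smaller, yet each keeps the aromatic ring, so none tests its loss. No step beyond the scatter is therefore expected, though with wide uncertainty. The estimated step is a 1.3-fold higher number from compound 3 to compound 4 (0.11 log units; within the scatter). Compound 4 is expected at 6000 nM, within an estimated range of 1800 nM to 20000 nM.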

Compound 4, half-maximal inhibitory concentration: 11700 nM
For compound 4 the middle estimate is 2.0-fold (0.29 log units) below the measured one; the measured number falls inside the stated range.
By their numbers in this assay, from the lowest: compound 2; then compounds 1 and 3 (each within the scatter of the next); then compound 4.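

Replacing the aromatic ring with hydrogen, which cuts 2,5-difluorobenzyl back to methyl, gives a weaker compound in every comparison (a 2.5-fold higher number from compound 3 to compound 4 (0.40 log units; beyond the scatter)) (a 2.7-fold higher number from compound 1 to compound 4 (0.44 log units; beyond the scatter)) (a 10-fold higher number from compound 2 to compound 4 (1.01 log units; beyond the scatter)). All three benzyl compounds therefore have lower numbers than compound 4, and the gap is widest for the 4-fluorophenyl group. No measurement here explains this difference.

Going by these compounds, whether an ethyl group or a longer propyl chain would recover part of this gap remains open. So does whether a chain ending in an amine could stand in for the benzyl group.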